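Urea aryl swap: chloro to trifluoromethyl on the pyrazole series

The compounds below may be only part of what the source reports. "The series", "measured", "known", "first", "only" and "open" are said of these compounds alone.

Measured so far in a functional assay on T47D cells (Homo sapiens) for inhibition, read by sulforhodamine B assay, with a stated time of 48 h; on this read-out higher numbers stand for weaker inhibition of growth and lower numbers for stronger inhibition of growth:
Compound 1 `COc1cc(-c2nn(-c3cccc(NC(=O)Nc4cc(C(F)(F)F)cc(C(F)(F)F)c4)c3)cc2-c2ccncc2)ccc1Cl` gives > 50000 nM, a limit of the assay.
Compound 2 `COc1cc(-c2nn(-c3cccc(NC(=O)Nc4ccc(Cl)c(Cl)c4)c3)cc2-c2ccncc2)ccc1Cl` gives > 50000 nM, also a limit of the assay.
Compound 3 `O=C(Nc1cccc(-n2cc(-c3ccncc3)c(-c3ccc(Cl)c(O)c3)n2)c1)Nc1ccc(Cl)c(Cl)c1` gives 17900 nM.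

Among the compounds with values here, compound 3 is the only member with a number in this assay; the other two sit at the limit of > 50000 nM in this assay, at which 2 of the 3 values shown sit. Within the data shown here, the one step between measured compounds, an at least 2.7-fold lower number from compound 2 to compound 3 (0.44 log units; beyond the scatter), concerns the oxygen on the other aromatic ring and does not touch the urea aryl, so it gives no direct reading on the change now proposed.

Compound 4 `O=C(Nc1cccc(-n2cc(-c3ccncc3)c(-c3ccc(Cl)c(O)c3)n2)c1)Nc1ccc(Cl)c(C(F)(F)F)c1` arises from compound 3 through (trifluoromethyl in place of chloro on an aromatic carbon). Among the measured compounds shown here, the only other information on the urea aryl comes from compound 1 and compound 2, where bis(trifluoromethyl) and dichloro both return limits, so no order between these groups can be drawn. For the measured compounds named here, no measured step bears directly on the chloro-to-trifluoromethyl swap.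

The expectation for compound 4 is therefore a step of a 1.1-fold higher number from compound 3 to compound 4 (0.05 log units; within the scatter), not beyond the scatter, with a fair chance that this assay again returns only a limit. The estimate for compound 4 in this assay is 20000 nM, with a range from 7000 nM to 50000 nM.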

Compound 4, concentration for total growth inhibition: > 32500 nM
Compound 4: no number, only a limit (the forecaster's own chance of this, stated with the estimate: 35%); middle value at least 1.6-fold (0.21 log units) from the limit.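

Within the data shown here, compound 3 and compound 4 give the first direct reading on the urea aryl, and in this assay the change from 3,4-dichlorophenyl to 4-chloro-3-(trifluoromethyl)phenyl brings no gain, with an at least 1.8-fold higher number from compound 3 to compound 4 (0.25 log units; that floor lies within the scatter) as the step. Compound 4 gives > 32500 nM, which is a limit of the assay and not a number. Whether the change costs anything beyond the scatter cannot be read from this floor, as the reading rests on a limit: the limit of > 32500 nM in this assay, at which 1 of the 4 values shown sits.

Open, going by these compounds, is whether a urea aryl carrying a carboxylic acid or an amine in place of trifluoromethyl would give a lower number in this assay than compound 3, which stands at 17900 nM. Also open, on these data alone, is whether hydrogen in place of methyl on the oxygen, which gave an at least 2.7-fold lower number from compound 2 to compound 3 (0.44 log units; beyond the scatter), has a comparable effect when the urea aryl carries two trifluoromethyl groups, as in compound 1.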